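This account rests on a few compounds, and the source may have more. Where it says the series, first, only, none or still open, it means among the compounds named here.

Measured compounds in a functional assay on MCF7 cells (Homo sapiens) for cytotoxicity, read by MTT assay, with a stated time of 48 h; a higher number here means a weaker inhibitor, a lower number a stronger inhibitor:
Compound 1 `CCN(CC)c1ccc2cc(C(=O)c3ccc(N4CCN(C(=O)CN5CCNCC5)CC4)cc3)oc2c1`: 5340 nM
Compound 2 `CCN(CC)c1ccc2cc(C(=O)c3ccc(N4CCN(C(=O)CN5CCN(Cc6ccc(F)c(F)c6)CC5)CC4)cc3)oc2c1`: 9220 nM
Compound 3 `CCN(CC)c1ccc2cc(C(=O)c3ccc(N4CCN(C(=O)CN5CCN(Cc6ccc(C#N)cc6)CC5)CC4)cc3)oc2c1`: > 40000 nM, a limit of the assay and not a number

Compound 3 thus stands at the limit of > 40000 nM in this assay, at which 1 of the 3 values shown sits, and is the only one of the three without a number. Compound 4 `CCN(CC)c1ccc2cc(C(=O)c3ccc(N4CCN(C(=O)CN5CCN(CC(C)=O)CC5)CC4)cc3)oc2c1` differs from it by acetyl in place of 4-cyanophenyl on a saturated chain carbon bound to an amine nitrogen in a ring. Among the compounds with values here, two measured steps bear on this change: an at least 7.4-fold higher number from compound 1 to compound 3 (0.87 log units; beyond the scatter) and an at least 4.3-fold higher number from compound 2 to compound 3 (0.63 log units; beyond the scatter), both beyond the scatter and both ending at the limit, whereas a 1.7-fold higher number from compound 1 to compound 2 (0.24 log units; within the scatter). Replacing the aromatic group with the smaller acetyl is expected to bring compound 4 back into the measurable range. Compound 4 is estimated at 12000 nM, with a range from 4000 nM to 40000 nM. The expected step is therefore an at least 3.3-fold lower number from compound 3 to compound 4 (0.52 log units; beyond the scatter).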

Compound 4, half-maximal inhibitory concentration: 11000 nM
Compound 4: the middle estimate sits 1.1-fold (0.04 log units) above what was measured, within the range that was stated.
By their numbers in this assay, from the lowest: compounds 1, 2 and 4 (each within the scatter of the next, the first and the last beyond it). At a limit, above all of these: compound 3.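

In this assay, acetyl in place of 4-cyanophenyl gives an at least 3.6-fold lower number from compound 3 to compound 4 (0.56 log units; beyond the scatter) and so shows that a measurable value at this position does not need an aromatic ring. Against 3,4-difluorophenyl, acetyl gives a 1.2-fold higher number from compound 2 to compound 4 (0.08 log units; within the scatter) and cannot be told apart from it, which leaves compound 3 alone out of line among the substituted compounds. Against hydrogen on this nitrogen, 2-oxopropyl gives a 2.1-fold higher number from compound 1 to compound 4 (0.31 log units; beyond the scatter) and is the first substituent here with a number beyond the scatter.

On these data alone, how far compound 3 really lies from the others stays open, since its value is a limit and not a number: the limit of > 40000 nM in this assay, at which 1 of the 4 values shown sits. As far as these compounds go, whether a carboxylic acid or a longer chain at this position would keep a measurable value also stays open.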